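Sulfonyl aryl swap on the anilide sulfonamide core

The compounds below may be only part of what the source reports. "The series", "measured", "known", "first", "only" and "open" are said of these compounds alone.

Compound 1 `CCN(CC)C(=O)CN(c1ccc(C)cc1)S(=O)(=O)c1cccc(Cl)c1` holds the higher of the two numbers measured in a functional assay on CHO cells for inhibition of Orexin receptor type 2 (Homo sapiens), read by FLIPR and calcium flux; on this read-out higher numbers stand for weaker inhibition and lower numbers for stronger inhibition: compound 1 gives 139 nM. Compound 2 `CCN(C(=O)CN(c1cc(N(C)C)ccc1Cl)S(=O)(=O)c1ccc(OC)c(OC)c1)c1ccn(C)n1`, which differs from it in several places at once, gives 7 nM in this assay, a gap beyond the scatter. Compound 3 `CCN(CC)C(=O)CN(c1ccc(C)cc1)S(=O)(=O)c1ccccc1F` keeps the core of compound 1 with a single change, (2-fluorophenyl in place of 3-chlorophenyl on a sulfonyl sulfur). For the measured compounds named here, no measured pair isolates this exchange, so its direction is open. The change is expected to produce a step of a 1.4-fold higher number from compound 1 to compound 3 (0.16 log units; within the scatter), probably within or close to the scatter. Compound 3 is therefore estimated at 200 nM, with a range from 70 nM to 600 nM.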

Compound 3, half-maximal inhibitory concentration: 3370 nM
The estimate for compound 3 lay 17-fold (1.23 log units) below the measured number, and the stated range ends below it.
By their numbers in this assay, from the lowest: compound 2; then compound 1; then compound 3.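

On the sulfonyl sulfur the aryl group is far from interchangeable: in this assay, 2-fluorophenyl in place of 3-chlorophenyl gives a 24-fold higher number from compound 1 to compound 3 (1.38 log units; beyond the scatter) and marks a clear weakening of inhibition. This large step comes with no change in the heavy-atom count of the group or in its counted hydrogen-bond donors and acceptors, so those counts do not track the read-out in this pair. No supporting data bear on what drives the step.

As far as these compounds go, the halogen and its position are changed together here, so their separate contributions remain open. Also open, from the compounds shown here alone, is how a phenyl carrying no halogen, or one carrying an amine, would read on this sulfur.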